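This account rests on a few compounds, and the source may have more. Where it says the series, first, only, none or still open, it means among the compounds named here.

Compound 1 `O=C1C(=O)N(CCCCn2cc(COc3cc(=O)oc4ccccc34)nn2)c2ccc(Cl)cc21` carries a chloro group on the fused ring of its core and a four-carbon chain linking that core to the triazole and coumarin part. In a functional assay on THP-1 cells (Homo sapiens) for inhibition, read by sulforhodamine B assay, with a stated time of 48 h, tested at 50 uM (a higher number here means more inhibition of growth at the concentration tested, a lower number less inhibition of growth), compound 1 gives 71%. Compound 2 `O=C1C(=O)N(CCCn2cc(COc3cc(=O)oc4ccccc34)nn2)c2ccc(I)cc21`, which has an iodo group in the corresponding position and a shorter chain, gives in this assay 67%. Among the measured compounds shown here, of the two numbers measured so far, compound 1 has the higher one, but compound 2 lies so close to it that the gap falls within the usual scatter of repeated measurements, so no order between the two can be drawn.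

Compound 3 `O=C1C(=O)N(CCCCn2cc(COc3cc(=O)oc4ccccc34)nn2)c2ccc(Br)cc21` has not yet been measured. It differs from compound 1 in a single place: bromo in place of chloro on an aromatic carbon. A halogen is swapped for a neighbouring halogen, with nothing else altered in the molecule.

Since the only other halogen variant seen here, compound 2, sits within the scatter of compound 1, the step of a number 1 percentage points lower from compound 1 to compound 3 (within the scatter) is expected to be small and not beyond the scatter. Compound 3 is therefore estimated to give about 70%, with a likely range from 58% to 82%.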

Compound 3, percent growth inhibition at one concentration: 63%
Beside the measured number, compound 3's estimate is 7 percentage points above it; the measured number falls inside the stated range.
By their numbers in this assay, from the lowest: compounds 3, 2 and 1 (each within the scatter of the next).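

Among the compounds shown here, this is the first pair here that differs in one place only, so the halogen on the aromatic carbon can be judged on its own: in this assay bromo in place of chloro gives a number 8 percentage points lower from compound 1 to compound 3 (within the scatter). At this position, then, exchanging these two halogens produces no difference that can be told apart from the ordinary spread of repeated measurements, and no order between chloro and bromo can be drawn. No measurement of any property of these groups accompanies the result, so nothing can be said about what lies behind the numbers.

The compounds shown leave open whether a group of another kind at this place, such as an amine or a methoxy group, would give a step beyond the scatter. Also open, going by these compounds, is what the linking chain contributes: compound 2 differs from compound 1 in both its halogen and its chain, so the two changes cannot be separated, and the effect of a longer chain remains unknown.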